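Replacing the basic amide chain with a carboxy group

This account rests on a few compounds, and the source may have more. Where it says the series, first, only, none or still open, it means among the compounds named here.

For the measured compounds named here, in a functional assay on PC-3 cells (Homo sapiens) for antiproliferative activity, read by MTT assay, with a stated time of 72 h (a higher number here means a weaker inhibitor, a lower number a stronger inhibitor), compound 2 `CCn1cc(C(CC)(CC)c2ccc(C#CC(O)(CC)CC)c(C)c2)cc1C(=O)NCCCN(C)C` gives 15100 nM, the only numerical value available so far. Compound 1 `CCCCC(=O)c1ccc(C(CC)(CC)c2ccc(C#CC(O)(CC)CC)c(C)c2)n1CC` is reported only as a limit, > 50000 nM. Compound 3 `CCn1cc(C(CC)(CC)c2ccc(C#CC(O)(CC)CC)c(C)c2)cc1C(=O)NCC(=O)O` keeps the core of compound 2 and carries carboxy in place of 2-(dimethylamino)ethyl on a saturated chain carbon bound to an amide-type nitrogen. Going by the values given here, no measured pair isolates this change, so the expectation is loose: a moderate loss of inhibition in this assay, possibly reaching a limit. The expected step of a 2.3-fold higher number from compound 2 to compound 3 (0.37 log units; beyond the scatter) is an estimate that points toward weaker inhibition. For compound 3 the estimated value is 35000 nM, with an expected range of 14000 nM to 80000 nM.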

Compound 3, half-maximal inhibitory concentration: 6300 nM
Compound 3: middle estimate off by 5.6-fold (0.74 log units), on the high side; the measured number lies below the stated range.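

In this assay the change from 3-(dimethylamino)propyl to carboxymethyl on the amide-type nitrogen gives a 2.4-fold lower number from compound 2 to compound 3 (0.38 log units; beyond the scatter) and so a stronger inhibitor. The dimethylamino end group is therefore not required for activity here, and this position accepts a carboxy group. No measurement shown gives a cause for this step.

Chain length and end group change together in this pair, so their contributions remain unseparated. A longer chain ending in a carboxylic acid, or a two-carbon chain ending in a dimethylamino group, would help to separate them.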